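Thiazole acetic acids: difluorination of the aryl ring

A few compounds are considered here, and "the series" means these few. Any claim that something is new, unique, unknown or untested is made for them only; others in the source may bear on it.

Three compounds have numbers in an in vitro assay on HEK385-7 cells for displacement of a labelled ligand from prostaglandin D2 receptor 2 (Homo sapiens); a higher number here means a weaker inhibitor, a lower number a stronger inhibitor. Compound 1 `Nc1nc(-c2ccc(Cl)cc2)c(CC(=O)O)s1` gives only a limit, > 100000 nM, and no number. Compound 2 `O=C(O)Cc1sc(CS(=O)(=O)c2ccc(Cl)cc2)nc1-c1ccc(Cl)cc1` gives 1500 nM. Compound 3 `O=C(O)Cc1sc(C(c2ccccc2)c2ccccc2)nc1-c1ccccc1` gives 570 nM, the lowest of the two numbers shown; the gap to compound 2 lies beyond the scatter. Compound 1 sits at a limit of this assay, as the relevant line shows: the limit of > 100000 nM in this assay, at which 1 of the 3 values shown sits.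

Compound 4 `O=C(O)Cc1sc(C(c2ccccc2)c2ccccc2)nc1-c1ccc(F)c(F)c1` differs from compound 3 in one place: 3,4-difluorophenyl in place of phenyl on an aromatic carbon of the shared core. Among the measured compounds shown here, no measured pair in this set changes the aryl ring in this way, so the size of the step is not known from the data. A small step is expected, if any, within or close to the scatter, more likely towards a lower number than a higher one. Compound 4 is therefore expected to give about 400 nM, with a range from 150 nM to 1200 nM, which means an estimated step of a 1.4-fold lower number from compound 3 to compound 4 (0.15 log units; within the scatter).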

Compound 4, half-maximal inhibitory concentration: 4.1 nM
For compound 4 the middle estimate is 98-fold (1.99 log units) above the measured one, outside the stated range (below it).
By their numbers in this assay, from the lowest: compound 4; then compound 3; then compound 2. At a limit, above all of these: compound 1.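

In this assay, the aryl ring on this aromatic carbon, next to the ring nitrogen, turns out to be a strong handle on the number: 3,4-difluorophenyl in place of phenyl gives a 140-fold lower number from compound 3 to compound 4 (2.14 log units; beyond the scatter). Among the compounds shown here, this is the first single-place change that can be read, and the rest of the structure stays the same. The counts of hydrogen-bond donors, hydrogen-bond acceptors and net charge also stay unchanged, and nothing measured here accounts for the size of the step.

The compounds shown leave open whether a single fluorine on this ring carries the step or both are needed. Also open, going by these compounds, is whether a methoxy group or a nitrile on the same ring would do the same, and whether the step survives a change of the large group on the shared core.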